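Methyl in Place of Fluoro: What to Expect for Compound 4

The source may hold more compounds than are shown below. What is called first, only, known or untested is meant among the compounds shown, and "the series" means these compounds.

Compound 1, `Oc1ccccc1/C=N/c1ccc(OCc2ccccc2)cc1`, gives > 200000 nM in a functional assay, with a stated time of 30 min (on this read-out higher numbers stand for weaker inhibition and lower numbers for stronger inhibition), a limit of the assay rather than a number.
Compound 2, `Oc1ccc(F)cc1/C=N/c1ccc(OCc2ccccc2)cc1`, gives > 200000 nM in this assay, likewise a limit.
Compound 3, `COc1ccc(/C=N/c2ccc(OCc3ccccc3)cc2)c(O)c1`, gives > 200000 nM in this assay, likewise a limit.

Within the data shown here, compound 2 thus stands where every value so far stands: at the limit of > 200000 nM in this assay, at which 3 of the 3 values shown sit, with no number beneath it. Compound 4, `Cc1ccc(O)c(/C=N/c2ccc(OCc3ccccc3)cc2)c1`, differs from compound 2 in one place.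

methyl in place of fluoro on an aromatic carbon

Among the measured compounds shown here, two measured steps touch the same aromatic carbon of the shared core. The step that the two limits leave unreadable from compound 1 to compound 2 and the step that the two limits leave unreadable from compound 1 to compound 3 both run between limits, so their size is not readable, and neither tells whether a substituent at this position moves the read-out at all. For the measured compounds named here, with nothing readable to build on, the change from compound 2 to compound 4 is expected to give a number no higher from compound 2 to compound 4 (the limit leaves the size open), that is, no step that the assay can show. Compound 4 is therefore estimated to sit at the same limit in this assay, near 200000 nM, with a range from 100000 nM to 400000 nM.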

Compound 4, half-maximal inhibitory concentration: > 200000 nM
Compound 4 gave a limit, no number (the forecaster's own chance of this, stated with the estimate: 85%); the middle value sits exactly at the limit.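

Neither the step from compound 2 to compound 4 nor the one from compound 1 to compound 4 can be read, since each compound gives only a limit, not a number: the limit of > 200000 nM in this assay, at which 4 of the 4 values shown sit.

The compounds shown leave open whether any substituent at this aromatic carbon changes the inhibition at all.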